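This account rests on a few compounds, and the source may have more. Where it says the series, first, only, none or still open, it means among the compounds named here.

In a functional assay on A549 cells (Homo sapiens) for antiproliferative activity, read by MTT assay, with a stated time of 72 h (a lower number here means a stronger inhibitor of growth, a higher number a weaker inhibitor of growth), compound 1 `COc1cc(OC)n2cc(-c3ccc(N)cc3)nc2n1` reaches only the limit of the assay, > 100000 nM. Compound 2 `COc1cc(OC)n2cc(-c3ccc(NCc4ccccc4)cc3)nc2n1` likewise gives only a limit, > 100000 nM. The change between them is benzyl in place of hydrogen on a nitrogen on an aromatic ring, and the corresponding step, a step that the two limits leave unreadable from compound 1 to compound 2, cannot be read because the limit of > 100000 nM in this assay, at which 3 of the 3 values shown sit, holds both values. Compound 3 `Cc1ccn2cc(-c3ccc(N)cc3)nc2c1` also stops at a limit, > 100000 nM. How the core of compound 3 differs from the core of compound 1 is not broken down here. Compound 4 `Cc1ccn2cc(-c3ccc(NCc4ccccc4)cc3)nc2c1` carries the same change relative to compound 3, (benzyl in place of hydrogen on a nitrogen on an aromatic ring), at a place described in identical words. A step that the limit leaves unreadable from compound 3 to compound 4 of about nothing is expected from compound 3 to compound 4 because the limit of > 100000 nM in this assay, at which 3 of the 3 values shown sit, shows every measured value at the limit. Compound 4 is therefore estimated at 150000 nM, expected to fall between 50000 nM and 500000 nM.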

Compound 4, concentration for 50% growth inhibition: 5100 nM
Estimate against measurement, compound 4: 29-fold (1.47 log units) above; measured number outside the range, below it.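

In this assay, benzyl in place of hydrogen on a nitrogen on an aromatic ring gives an at least 19-fold lower number from compound 3 to compound 4 (1.29 log units; beyond the scatter), so on the core of compound 3 the change yields a measured value in place of a limit. On the core of compound 1, compound 2 stays at > 100000 nM, which is a limit of the assay and not a number, and the step to it cannot be read. As far as these compounds go, the large step therefore does not visibly carry over to the core of compound 1, yet the size of the effect there remains unknown, and two cores support no general rule.

From the compounds shown here alone, it remains open whether the benzyl ring itself matters or whether other groups on that nitrogen would serve equally. A methyl, a phenethyl chain or an acetyl group there would bear on this, and none is among the compounds shown.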